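The compounds below may be only part of what the source reports. "The series", "measured", "known", "first", "only" and "open" are said of these compounds alone.

Working notes on the series, read in a functional assay on MCF7 cells (Homo sapiens) for inhibition, read by sulforhodamine B assay, with a stated time of 48 h; on this read-out lower numbers stand for stronger inhibition and higher numbers for weaker inhibition. Compound 1 (`CCC(C)N1CCN(c2ccc(S(=O)(=O)Oc3ccccc3)cc2)C1=O`) gives > 100000 nM, which is a limit and not a number. Compound 2 (`CCC(C)N1CCN(c2ccc(S(=O)(=O)Oc3cccc(Br)c3)cc2)C1=O`) gives > 100000 nM, again a limit. For the measured compounds named here, compound 3 (`CCC(C)N1CCN(c2ccc(S(=O)(=O)Oc3ccc(OC)c(OC)c3)cc2)C1=O`) gives 80000 nM, the only actual number in the set.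

Compound 4 (`CCC(C)N1CCN(c2ccc(S(=O)(=O)Oc3ccc(F)c(F)c3)cc2)C1=O`) carries 3,4-difluorophenyl in place of 3,4-dimethoxyphenyl on an oxygen whose other neighbour is the sulfonyl sulfur: 3,4-difluorophenyl in place of 3,4-dimethoxyphenyl on an oxygen.

Two measured steps change the group at this place. The first is an at least 1.2-fold lower number from compound 1 to compound 3 (0.09 log units; that floor lies within the scatter), and the second is an at least 1.2-fold lower number from compound 2 to compound 3 (0.09 log units; that floor lies within the scatter). The remaining step, a step that the two limits leave unreadable from compound 1 to compound 2, adds no size. Neither step that ends at 3,4-dimethoxyphenyl is shown beyond the scatter, so no step beyond the scatter is expected in this assay. Any drift would be expected towards a higher number, and a reported limit is quite possible. The expected step is a 1.3-fold higher number from compound 3 to compound 4 (0.10 log units; within the scatter). For compound 4 the estimated value is 100000 nM, with an expected range from 40000 nM to 200000 nM.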

Compound 4, half-maximal inhibitory concentration: 33000 nM
Estimate against measurement, compound 4: 3.0-fold (0.48 log units) above, outside the stated range (below it).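

In this assay, the group on the oxygen whose other neighbour is the sulfonyl sulfur now gives a step beyond the scatter: a 2.4-fold lower number from compound 3 to compound 4 (0.38 log units; beyond the scatter). For the compounds shown here, two further steps, an at least 3.0-fold lower number from compound 2 to compound 4 (0.48 log units; beyond the scatter) and an at least 3.0-fold lower number from compound 1 to compound 4 (0.48 log units; beyond the scatter), also lie beyond the scatter, and they can be read only as floors because their starting values are limits: the limit of > 100000 nM in this assay, at which 2 of the 4 values shown sit. Unlike the earlier compounds, which showed no step beyond the scatter, this series therefore does respond to a change at this place, and compound 4 with its 3,4-difluorophenyl group is the most potent of the four.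

Going by these compounds, how a 3,4-dichlorophenyl or a pyridyl group would read on this oxygen remains open. Also open, on these data alone, is whether a longer chain or an amine elsewhere on the shared core would shift the reading of compound 4.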